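Sulfonate series: cytotoxicity limits and an unsubstituted benzyl analogue

The compounds below may be only part of what the source reports. "The series", "measured", "known", "first", "only" and "open" are said of these compounds alone.

Measured compounds:
Compound 1, `CCC1(Cc2ccccc2)OS(=O)(=O)C=C1OCc1ccc(Cl)c(Cl)c1`; in an ADME assay on HEL cells (Homo sapiens) for cytotoxicity, with a stated time of 3 days (on this read-out higher numbers stand for lower toxicity in this test and lower numbers for higher toxicity in this test), compound 1 gives >= 20000 nM, a limit of the assay.
Compound 2, `CCC1(Cc2ccccc2)OS(=O)(=O)C=C1OCc1ccc([N+](=O)[O-])cc1`; in this assay compound 2 gives >= 80000 nM, a limit of the assay.
Compound 3, `CCC1(Cc2ccccc2)OS(=O)(=O)C=C1OCc1ccc(C)cc1`; in this assay compound 3 gives >= 16000 nM, a limit of the assay.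

Compound 1 stands only at a limit, and the two further values shown are limits as well (the limit of >= 20000 nM in this assay, at which 1 of the 3 values shown sits). Going by the values given here, no compound in the set returned a number in this assay.

Compound 4, `CCC1(Cc2ccccc2)OS(=O)(=O)C=C1OCCc1ccccc1`, has not been measured. It differs from compound 1 in one place: benzyl in place of 3,4-dichlorophenyl on a saturated chain carbon bound to an oxygen on an unsaturated carbon.

The measured steps at this position are a step that the two limits leave unreadable from compound 1 to compound 2 and a step that the two limits leave unreadable from compound 1 to compound 3; the step that the two limits leave unreadable from compound 2 to compound 3 is likewise not readable, since every value involved is a limit of >= 16000 nM in this assay, at which 1 of the 3 values shown sits (the limit of >= 80000 nM in this assay, at which 1 of the 3 values shown sits). No step size can therefore be carried over to the change from compound 1 to compound 4. The expectation is that compound 4 also returns a limit in this assay, with no readable step beyond the scatter, so that the estimated step that the limit leaves unreadable from compound 1 to compound 4 is small. Compound 4 is expected to give 40000 nM, within 16000 nM to 100000 nM.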

Compound 4, minimum cytotoxic concentration: >= 20000 nM
Compound 4: no number, only a limit (the forecaster's own chance of this, stated with the estimate: 85%); the middle value lies beyond the limit too.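

In this assay compound 4 gives >= 20000 nM, a limit of the assay. Going by these compounds alone, no step from compound 1, compound 2 or compound 3 to compound 4 can be read, and all four values are limits. The compounds shown leave open at what concentration any of them becomes cytotoxic and whether these changes on the benzyl-type side chain alter that concentration.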